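The compounds below may be only part of what the source reports. "The series", "measured", "known", "first", "only" and "open" are said of these compounds alone.

Three compounds of a shared core, compound 1 `CC(C)[C@H](NC(=O)COc1cccc2ccccc12)C(=O)N[C@@H](CC(=O)O)C(=O)COc1ccccc1C(F)(F)F`, compound 2 `CC(=O)Nc1cccc(OCC(=O)[C@H](CC(=O)O)NC(=O)[C@@H](NC(=O)COc2cccc3ccccc23)C(C)C)c1` and compound 3 `CC(C)[C@H](NC(=O)COc1cccc2ccccc12)C(=O)N[C@@H](CC(=O)O)C(=O)COc1ccc(F)c(F)c1F`, have been tested in a functional assay on Jurkat cells (Homo sapiens); a lower number here means a stronger inhibitor, a higher number a weaker inhibitor. Compound 1 gives only a limit there, > 100000 nM. Compound 2 likewise gives only a limit, > 100000 nM. Compound 3 gives a number, 35800 nM, so compound 2 stands at the weak end of what is known, together with compound 1 at the limit of > 100000 nM in this assay, at which 2 of the 3 values shown sit.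

The step from compound 2 to compound 4, `CC(C)[C@H](NC(=O)COc1cccc2ccccc12)C(=O)N[C@@H](CC(=O)O)C(=O)COc1ccc([N+](=O)[O-])cc1F`, exchanges the aryl group on the oxygen on the saturated carbon: 2-fluoro-4-nitrophenyl in place of 3-acetamidophenyl on an oxygen on a saturated carbon. For the measured compounds named here, two measured steps bear on it. The exchange of the same group for a fluorinated phenyl gave an at least 2.7-fold lower number from compound 2 to compound 3 (0.44 log units; beyond the scatter), and the related change from compound 1 gave an at least 2.7-fold lower number from compound 1 to compound 3 (0.44 log units; beyond the scatter), while a step that the two limits leave unreadable from compound 1 to compound 2. Going by the values given here, since a fluorine-bearing phenyl in place of 3-acetamidophenyl lowered the number at least modestly in this assay, a step of similar direction is expected here, though the 2-fluoro-4-nitrophenyl group is not identical to the one in compound 3 and the gain may be smaller.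

Compound 4 is therefore expected to give about 45000 nM in this assay, within a range from 12000 nM to 150000 nM, an expected step of an at least 2.2-fold lower number from compound 2 to compound 4 (0.34 log units; beyond the scatter).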

Compound 4, half-maximal inhibitory concentration: 30300 nM
Compound 4: middle estimate off by 1.5-fold (0.17 log units), on the high side; the measured number falls inside the stated range.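

With compound 4, a second aryl group on the oxygen on a saturated carbon gives a readable number in this assay, and the gain over the 3-acetamidophenyl group is slightly better bounded: an at least 3.3-fold lower number from compound 2 to compound 4 (0.51 log units; beyond the scatter), and the same bound holds against the 2-(trifluoromethyl)phenyl group, an at least 3.3-fold lower number from compound 1 to compound 4 (0.51 log units; beyond the scatter). The 2-fluoro-4-nitrophenyl and 2,3,4-trifluorophenyl groups cannot be told apart here, a 1.2-fold lower number from compound 3 to compound 4 (0.07 log units; within the scatter), so this position accepts two differently substituted phenyl groups with no separable change in the number. Fluorine alone does not account for the pattern among these compounds, since compound 1 goes against it, carrying fluorine in its 2-(trifluoromethyl)phenyl group yet giving only a limit, > 100000 nM.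

For the compounds shown here, whether the nitro group or the single fluorine of compound 4 accounts for its number remains open, and a plain 4-nitrophenyl or 2-fluorophenyl group on the same oxygen would separate the two. The true sizes of the steps from compound 1 and compound 2 also stay unknown, as each of these compounds gives only a limit: the limit of > 100000 nM in this assay, at which 2 of the 4 values shown sit.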